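From a Bromophenyl to a Benzyl Group on the Ring Nitrogen

The compounds below may be only part of what the source reports. "The series", "measured", "known", "first", "only" and "open" are said of these compounds alone.

The series rests on the shared core of compound 1 `CC(C)n1ncc2c(C(=O)Nc3ccccc3)cccc21`, which in a functional assay on MCF7 cells (Homo sapiens) for inhibition, read by MTT assay, with a stated time of 72 h (a higher number here means a weaker inhibitor, a lower number a stronger inhibitor), gives 19700 nM. Compound 2 `CC(C)n1ncc2c(C(=O)NCc3cn(-c4cccc(Br)c4)nn3)cccc21` carries a 3-bromophenyl group on an aromatic nitrogen of a five-membered aromatic ring with 3 nitrogen. In this assay compound 2 reaches only a limit, > 40000 nM. Compound 3 `Cc1cccc(-n2cc(CNC(=O)c3cccc4c3cnn4C(C)C)nn2)c1` bears a methyl in place of that bromo. In this assay compound 3 likewise stands at a limit, > 40000 nM. Going by the values given here, the single change measured within this pair, methyl in place of bromo on an aromatic carbon, gives a step that the two limits leave unreadable from compound 2 to compound 3, so it tells nothing about size. What frames the picture is the limit of > 40000 nM in this assay, at which 2 of the 3 values shown sit; compound 2 sits there without a number of its own.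

Compound 4 `CC(C)n1ncc2c(C(=O)NCc3cn(Cc4ccccc4)nn3)cccc21` differs from compound 2 by benzyl in place of 3-bromophenyl on an aromatic nitrogen. Among the compounds with values here, no measured step describes this change, and the step from compound 2 to compound 3 is unreadable, so nothing in hand points to a gain. Compound 4 is therefore expected to remain near the limit, with a number no higher from compound 2 to compound 4 (the limit leaves the size open) amounting to little, if anything, beyond the scatter. The estimate for compound 4 in this assay is 40000 nM, ranging from 12000 nM to 120000 nM.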

Compound 4, half-maximal inhibitory concentration: 9170 nM
Compound 4: the middle estimate sits 4.4-fold (0.64 log units) above what was measured; measured number below the stated range.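

Going by these compounds alone, on the aromatic nitrogen of the five-membered ring, benzyl in place of 3-bromophenyl gives an at least 4.3-fold lower number from compound 2 to compound 4 (0.63 log units; beyond the scatter), the first change at this place with a readable direction in this assay. Benzyl in place of 3-methylphenyl gives an at least 4.3-fold lower number from compound 3 to compound 4 (0.63 log units; beyond the scatter), so compound 4 separates from both earlier compounds, even though the group that enters has the same count of heavy atoms as 3-bromophenyl and the same single six-membered aromatic ring of carbon only. Compound 2 and compound 3 both stand at a limit, so the step between them cannot be read and the true size of both new steps remains unknown: the limit of > 40000 nM in this assay, at which 2 of the 4 values shown sit.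

The compounds shown do not separate the carbon link that benzyl adds from the loss of the substituent on the ring, as compound 4 differs from compound 2 and compound 3 in both respects. Going by these compounds, an unsubstituted phenyl, a 3-bromobenzyl or a longer chain such as 2-phenylethyl on this nitrogen would bear on that question, and how any of them would read in this assay remains open.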